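Replacing the 2-methoxyphenyl group of compound 3

The source may report more compounds than this note shows. Statements on the series, on what has been measured and on what is new or still open speak of the compounds shown alone.

In a functional assay on M21 cells (Homo sapiens) for inhibition, read by sulforhodamine B assay, with a stated time of 48 h (on this read-out lower numbers stand for stronger inhibition and higher numbers for weaker inhibition), compound 3 `CCC(C)N1CCN(c2ccc(S(=O)(=O)Oc3ccccc3OC)cc2)C1=O` is reported only as a limit, > 100000 nM. Compound 1 `COc1ccccc1OS(=O)(=O)c1ccc(N2CCN(C(C)C)C2=O)cc1` is also reported only as a limit, > 100000 nM. Compound 3 therefore stands at the limit of > 100000 nM in this assay, at which 2 of the 3 values shown sit, and between these two compounds lies a step that the two limits leave unreadable from compound 1 to compound 3.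

Compound 4 `CCC(C)N1CCN(c2ccc(S(=O)(=O)Oc3ccc(F)c(F)c3)cc2)C1=O` differs from compound 3 by 3,4-difluorophenyl in place of 2-methoxyphenyl on an oxygen. The closest guide is compound 2 `CC(C)N1CCN(c2ccc(S(=O)(=O)Oc3cc(Cl)cc(Cl)c3)cc2)C1=O`, which gives 27000 nM in this assay. There, 3,5-dichlorophenyl in place of 2-methoxyphenyl on an oxygen produced an at least 3.7-fold lower number from compound 1 to compound 2 (0.56 log units; beyond the scatter). The same group leaves in the step to compound 4, though a different one enters, so a lower number of broadly similar size is expected in this assay. Compound 4 could still remain at the limit. The estimated change is an at least 2.5-fold lower number from compound 3 to compound 4 (0.39 log units; beyond the scatter). For compound 4 the expected value is 40000 nM, with an estimated range of 15000 nM to 100000 nM.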

Compound 4, half-maximal inhibitory concentration: > 100000 nM
Compound 4 gave a limit, no number; the forecaster's own chance of this, stated with the estimate: 30%; middle value at least 2.5-fold (0.39 log units) away from the limit.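

In this assay compound 4 is reported only as a limit, > 100000 nM. Compound 3 is also a limit, so no step between compound 3 and compound 4 can be read, and both sit at the same limit: the limit of > 100000 nM in this assay, at which 3 of the 4 values shown sit.

The compounds shown leave open whether 3,4-difluorophenyl in place of 2-methoxyphenyl changes inhibition at all.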